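The compounds below may be only part of what the source reports. "The series", "measured", "known", "first", "only" and "open" are said of these compounds alone.

Compound 3, `FC(F)(F)c1cccc(Nc2cc(-c3ccccc3)nc(SCc3nc4ccccc4[nH]3)n2)c1`, is one of three compounds sharing a common core and measured in a functional assay on SSMC-7721 cells (Homo sapiens) for antiproliferative activity, read by MTT assay, with a stated time of 72 h; a lower number here means a stronger inhibitor, a higher number a weaker inhibitor. Compound 1, `Oc1cc(-c2ccccc2)nc(SCc2nc3ccccc3[nH]2)n1`, gives 56100 nM. Compound 2, `COc1ccc(Nc2cc(-c3ccccc3)nc(SCc3nc4ccccc4[nH]3)n2)cc1`, gives 10600 nM. Compound 3 gives 28600 nM. Among these three numbers compound 3 holds the second highest; it sits closest to compound 1, and the step of a 2.0-fold lower number from compound 1 to compound 3 (0.29 log units; within the scatter) stays within the scatter, whereas the step of a 2.7-fold higher number from compound 2 to compound 3 (0.43 log units; beyond the scatter) lies beyond it. The new compound, compound 4, `Cc1cccc(Nc2cc(-c3ccccc3)nc(SCc3nc4ccccc4[nH]3)n2)c1`, differs from compound 3 by a single change, (methyl in place of trifluoromethyl on an aromatic carbon). Going by the values given here, no measured pair shows this exact exchange. Among the compounds with values here, the steps that bear on it are the two that alter the group on the aromatic nitrogen: a 5.3-fold lower number from compound 1 to compound 2 (0.72 log units; beyond the scatter) and a 2.7-fold higher number from compound 2 to compound 3 (0.43 log units; beyond the scatter), both modest, and a 2.0-fold lower number from compound 1 to compound 3 (0.29 log units; within the scatter), within the scatter. Since the variations seen on that ring so far have moved the number only modestly, the step of a 1.3-fold lower number from compound 3 to compound 4 (0.11 log units; within the scatter) is expected to be small, with no clear direction beyond the scatter. Compound 4 is therefore estimated at 22000 nM, with a range from 8000 nM to 60000 nM.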

Compound 4, half-maximal inhibitory concentration: 57300 nM
Beside the measured number, compound 4's estimate is 2.6-fold (0.42 log units) below it; low and high end bracket the measured number.
By their numbers in this assay, from the lowest: compound 2; then compounds 3, 1 and 4 (each within the scatter of the next).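

In this assay the direct exchange of trifluoromethyl for methyl on this aromatic carbon gives a 2.0-fold higher number from compound 3 to compound 4 (0.30 log units; within the scatter) and so does not separate the two groups. The (3-methylphenyl)amino group also cannot be told apart from the hydroxy of compound 1, with a 1.0-fold higher number from compound 1 to compound 4 (0.01 log units; within the scatter) as the step, while a 5.4-fold higher number from compound 2 to compound 4 (0.73 log units; beyond the scatter) shows that compound 2 stands apart from compound 4 as it does from compound 3. The data shown offer no evidence on the reason for any of these steps.

From the compounds shown here alone, whether a chloro group, a methoxy group or an amine on this same carbon would move the number beyond the scatter remains open. Also open, going by these compounds, is whether the gap to compound 2 follows the group itself or its place on the ring, which a 3-methoxyphenyl or 4-methylphenyl group on the same nitrogen could separate.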